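Pyrimidin-2-yl for 1,1-difluoroethyl: expected exposure of compound 4

The source may hold more compounds than are shown below. What is called first, only, known or untested is meant among the compounds shown, and "the series" means these compounds.

In an ADME assay on the whole organism (plasma, strain 129/SvEvBrd x C57BL/6) for pharmacokinetics, with Mus musculus as the target, at a dose of 10 mg/kg by the oral route (on this read-out higher numbers stand for higher exposure at the dose given and lower numbers for lower exposure), compound 2 `CC(F)(F)c1nc([C@@H](O)[C@H](O)[C@H](O)CO)c[nH]1` gives 1190 ng.h/mL and compound 1 `CCc1[nH]c(C(C)=O)nc1[C@@H](O)[C@H](O)[C@H](O)CO` gives 1650 ng.h/mL, two values within the scatter of each other. Compound 3 `OC[C@@H](O)[C@@H](O)[C@H](O)c1c[nH]c(C(F)(F)C(F)(F)F)n1` gives 3060 ng.h/mL. Compound 4 `OC[C@@H](O)[C@@H](O)[C@H](O)c1c[nH]c(-c2ncccn2)n1` differs from compound 2 by pyrimidin-2-yl in place of 1,1-difluoroethyl on an aromatic carbon. For the measured compounds named here, the only measured step bearing on this place, a 2.6-fold higher number from compound 2 to compound 3 (0.41 log units; beyond the scatter), is modest and leaves a saturated chain there. Going by the values given here, no measured step puts a ring at this place, so the data support no direction. The expected step is a 1.2-fold higher number from compound 2 to compound 4 (0.07 log units; within the scatter), with nothing expected beyond the scatter. Compound 4 is estimated at 1400 ng.h/mL, with an expected range of 450 ng.h/mL to 4200 ng.h/mL.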

Compound 4, area under the concentration-time curve: 799 ng.h/mL
Beside the measured number, compound 4's estimate is 1.8-fold (0.24 log units) above it; low and high end bracket the measured number.
By their numbers in this assay, from the lowest: compounds 4, 2, 1 and 3 (each within the scatter of the next, the first and the last beyond it).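

In this assay, for the compounds shown here, a ring stands at this place for the first time, on an aromatic carbon between two ring nitrogen atoms, and the result is a 1.5-fold lower number from compound 2 to compound 4 (0.17 log units; within the scatter). Replacing 1,1-difluoroethyl with pyrimidin-2-yl therefore keeps exposure within the scatter of compound 2, so a saturated chain is not required here for that level. No measured property is available to explain exposure in this series.

Still open, as far as these compounds go, is whether a phenyl ring or an amine on this carbon would move exposure beyond the scatter.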